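Methyl on the Piperazine Nitrogen: What to Expect

The compounds below may be only part of what the source reports. "The series", "measured", "known", "first", "only" and "open" are said of these compounds alone.

Of the compounds shown here, three sharing one core have been tested in a functional assay on A-375 cells (Homo sapiens) for cytotoxicity, read by MTT assay, with a stated time of 72 h; a higher number here means a weaker inhibitor, a lower number a stronger inhibitor. Compound 1 `O=C1c2c[n+]([O-])c3ccccc3c2C(=O)c2c1c1ccccc1n2Cc1cn([C@H]2C[C@H](O)[C@@H](CO)O2)nn1` gives 390 nM in this assay. For the measured compounds named here, compound 2 `CC1(C)O[C@@H](CO)[C@H](Cn2cc(Cn3c4c(c5ccccc53)C(=O)c3c[n+]([O-])c5ccccc5c3C4=O)nn2)O1` gives 190 nM in this assay, and the step of a 2.1-fold lower number from compound 1 to compound 2 (0.31 log units; beyond the scatter) is the only single-point change among the measured compounds. Compound 3 `O=C1c2c[n+]([O-])c3ccccc3c2C(=O)c2c1c1ccccc1n2CCCCN1CCNCC1` gives 460 nM in this assay, the highest of the three numbers; compound 1 sits within the scatter of it, while compound 2 lies beyond the scatter on the lower side.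

Compound 4 `CN1CCN(CCCCn2c3c(c4ccccc42)C(=O)c2c[n+]([O-])c4ccccc4c2C3=O)CC1` is the unmeasured compound. It differs from compound 3 by methyl in place of hydrogen on an amine nitrogen in a ring. Going by the values given here, no measured step touches the amine nitrogen of the piperazin-1-yl group: the one measured step, from compound 1 to compound 2, exchanges a 4-hydroxy-5-(hydroxymethyl)oxolan-2-yl group on an aromatic nitrogen and offers no guide here. In the absence of any bearing precedent, the step of a 1.1-fold lower number from compound 3 to compound 4 (0.04 log units; within the scatter) is expected to remain within the scatter of this assay rather than move the number in either direction. Compound 4 is therefore estimated at 420 nM in this assay, with a range from 150 nM to 1200 nM.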

Compound 4, half-maximal inhibitory concentration: 30 nM
Compound 4: the middle estimate sits 14-fold (1.15 log units) above what was measured; measured number outside the range, below it.
By their numbers in this assay, from the lowest: compound 4; then compound 2; then compounds 1 and 3 (each within the scatter of the next).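

In this assay, the amine nitrogen of the piperazin-1-yl group turns out to be a sensitive position: methyl in place of hydrogen, a change of one carbon, gives a 15-fold lower number from compound 3 to compound 4 (1.19 log units; beyond the scatter). The earlier compounds shown here held no step at this nitrogen, so nothing in them showed that the number could move so far from such a small change, or that it would move downward. Nothing among the data shown accounts for the size of this step. As far as these compounds go, what an ethyl or an acetyl group on the same nitrogen would do remains open, so a single step cannot say whether the effect belongs to methyl alone. Also open, from the compounds shown here alone, is whether it would persist with a shorter chain carrying the 4-methylpiperazin-1-yl group.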